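Halogen swap on the fused ring of compound 1

This account rests on a few compounds, and the source may have more. Where it says the series, first, only, none or still open, it means among the compounds named here.

Compound 1, `CC1(C)CC(NC(=O)C2=NS(=O)(=O)c3ccccc3N2)c2cc(F)ccc2O1`, is the reference point of this set. In a functional assay on aorta (Rattus norvegicus, strain Wistar) for inhibition (a higher number here means that more compound is needed for the effect, a lower number that less compound is needed), compound 1 gives > 30000 nM, which is a limit of the assay and not a number. Compound 2, `Cc1ccc2c(c1)S(=O)(=O)N=C(C(=O)NC1CC(C)(C)Oc3ccc(F)cc31)N2`, carries a methyl in place of hydrogen on an aromatic carbon. In this assay compound 2 gives > 30000 nM, again a limit rather than a measured number. The step that the two limits leave unreadable from compound 1 to compound 2 cannot be sized because of the limit of > 30000 nM in this assay, at which 2 of the 2 values shown sit. So compound 1 stands at the limit of this assay, with no measured number to place it more closely and no readable step around it.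

Compound 3, `CC1(C)CC(NC(=O)C2=NS(=O)(=O)c3ccccc3N2)c2cc(Br)ccc2O1`, is not yet measured. Its change from compound 1 is bromo in place of fluoro on an aromatic carbon. Among the measured compounds shown here, no measured step bears on a bromo for fluoro exchange here, and the one measured step, from compound 1 to compound 2, gives no size at all. With nothing to move the expectation away from the limit, compound 3 is expected to remain at or near it, with a step that the limit leaves unreadable from compound 1 to compound 3 as the expected step. The estimate for compound 3 in this assay is 40000 nM, with a range from 10000 nM to 150000 nM.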

Compound 3, half-maximal effective concentration: > 30000 nM
Compound 3 was reported as a limit (the forecaster's own chance of this, stated with the estimate: 80%); the middle value does not contradict the limit.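

Compound 3 gives > 30000 nM in this assay, which is a limit of the assay and not a number, and the bromo for fluoro exchange between compound 1 and compound 3 yields no readable step: the limit of > 30000 nM in this assay, at which 3 of the 3 values shown sit.

The compounds shown leave open whether any change on the shared core gives a measurable value in this assay.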